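Changing the aryl group of compound 3

The source may hold more compounds than are shown below. What is called first, only, known or untested is meant among the compounds shown, and "the series" means these compounds.

In an ADME assay (liver) for metabolic stability, with Liver microsome (Homo sapiens) as the target, read by LC-MS, using microsomes, with a stated time of 30 min, tested at 4 uM (a higher number here means that more of the compound is left, a lower number that less of the compound is left), compound 3 (`CCc1ccccc1-c1nc2c(N3CCN(C)CC3)nc(C)nc2n1C1CCOCC1`) gives 33% and compound 1 (`Cc1nc(N2CCN(C)CC2)c2nc(-c3ccccc3C(F)(F)F)n(C3CCOCC3)c2n1`) gives 24%, so the two lie within the scatter of each other. Compound 2 (`Cc1nc(N2CCN(C)CC2)c2nc(-c3cccc(C(F)(F)F)c3)n(C3CCOCC3)c2n1`) gives 19% and lies clearly under compound 3. Compound 4 (`COc1ccc(-c2nc3c(N4CCN(C)CC4)nc(C)nc3n2C2CCOCC2)c(C)c1`) changes one group on an aromatic carbon of the shared core: 4-methoxy-2-methylphenyl in place of 2-ethylphenyl on an aromatic carbon (4-methoxy-2-methylphenyl in place of 2-ethylphenyl). Three measured swaps at this carbon bear on it: a number 5 percentage points lower from compound 1 to compound 2 (within the scatter) and a number 9 percentage points higher from compound 1 to compound 3 (within the scatter) stayed small, while a number 14 percentage points higher from compound 2 to compound 3 (beyond the scatter) was modest. None of them tested a methoxy group, so the direction is uncertain. A slight fall is expected, as a number 7 percentage points lower from compound 3 to compound 4 (within the scatter) in this assay suggests. Compound 4 is estimated at 26% (range 12% to 42%).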

Compound 4, percent of the compound remaining: 21%
Compound 4: the middle estimate sits 5 percentage points above what was measured; the measured number falls inside the stated range.
By their numbers in this assay, from the lowest: compounds 2, 4, 1 and 3 (each within the scatter of the next, the first and the last beyond it).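

In this assay, 4-methoxy-2-methylphenyl is the first group shown at this carbon to carry an oxygen, and replacing 2-ethylphenyl with it gives a number 12 percentage points lower from compound 3 to compound 4 (beyond the scatter), a modest step beyond the scatter. Against the two trifluoromethyl groups there is a number 2 percentage points higher from compound 2 to compound 4 (within the scatter) and a number 3 percentage points lower from compound 1 to compound 4 (within the scatter), so the new group falls with them in this read-out. No measured evidence explains these steps. As far as these compounds go, the step adds the methoxy group and swaps ethyl for methyl together, so their separate shares stay open, as does the outcome for an aryl group carrying an amine or a carboxylic acid.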